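Halogen swap on the aryl ring of a triazole series

This account rests on a few compounds, and the source may have more. Where it says the series, first, only, none or still open, it means among the compounds named here.

Measured compounds:
compound 1, `COc1cc(-c2ncnn2-c2ccc(F)cc2)cc(OC)c1OC`; in a functional assay on MCF7 cells (Homo sapiens) for antiproliferative activity, read by MTT assay, with a stated time of 72 h (a lower number here means a stronger inhibitor, a higher number a weaker inhibitor), compound 1 gives > 10000 nM, a limit of the assay.
compound 2, `COc1cc(-c2ncnn2-c2ccc(Cl)cc2)cc(OC)c1OC`; in this assay compound 2 gives > 10000 nM, also a limit.
compound 3, `COc1cc(-n2ncnc2-c2cccc(Cl)c2)cc(OC)c1OC`; in this assay compound 3 gives > 10000 nM, again a limit.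

From compound 2 to compound 1 the change is fluoro in place of chloro on an aromatic carbon. The step that the two limits leave unreadable from compound 2 to compound 1 cannot be read, since both values sit at the limit of > 10000 nM in this assay, at which 3 of the 3 values shown sit. The difference between the core of compound 2 and the core of compound 3 is not broken down here.

Compound 4, `COc1cc(-n2ncnc2-c2cccc(F)c2)cc(OC)c1OC`, is not yet measured and carries fluoro in place of chloro on an aromatic carbon. The place differs from the earlier change: there the fluoro stands para to a large group, here meta to a large group, so this is the same kind of change, not the same one.

For compound 4 the step that the limit leaves unreadable from compound 3 to compound 4 is expected to be unreadable as well, because compound 3 already sits at the limit of > 10000 nM in this assay, at which 3 of the 3 values shown sit. Compound 4 is estimated at 25000 nM, with a range from 6000 nM to 150000 nM.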

Compound 4, half-maximal inhibitory concentration: > 10000 nM
Compound 4: no number, only a limit; the forecaster's own chance of this, stated with the estimate: 85%; the middle value lies beyond the limit too.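

In this assay no new step can be read between compound 3 and compound 4, because both sit at a limit and give no number: the limit of > 10000 nM in this assay, at which 4 of the 4 values shown sit.

The compounds shown leave open how far each lies beyond that limit, and whether the change from 3-chlorophenyl to 3-fluorophenyl alters antiproliferative activity at all.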